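Removing the fluoro group from compound 3

The source may hold more compounds than are shown below. What is called first, only, known or untested is meant among the compounds shown, and "the series" means these compounds.

Three compounds have readings in a functional assay on HCT-116 cells (Homo sapiens) for antiproliferative activity, read by MTT assay, with a stated time of 48 h; on this read-out higher numbers stand for weaker inhibition and lower numbers for stronger inhibition. Compound 1 `Cc1cnc(Nc2ccc(Cl)cc2)nc1Nc1nc2ccccc2s1` gives > 50000 nM, which is a limit of the assay and not a number. Compound 2 `NS(=O)(=O)c1ccc(Nc2nccc(Nc3nc4ccccc4s3)n2)cc1` gives 5170 nM. Compound 3 `Cc1cnc(Nc2ccc(S(C)(=O)=O)cc2)nc1Nc1nc2ccc(F)cc2s1` gives 24000 nM, the highest of the two numbers; its nearest neighbour is compound 2, whose number is lower by a margin beyond the usual scatter. No two measured compounds differ in only one place, so no single step has been measured in this series, and nothing points to a cause for the gap between compound 2 and compound 3.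

Compound 4 `Cc1cnc(Nc2ccc(S(C)(=O)=O)cc2)nc1Nc1nc2ccccc2s1` differs from compound 3 by hydrogen in place of fluoro on an aromatic carbon. Compound 2 also carries no fluorine, but it differs from compound 3 in more than one place, so its number is not a guide to this change alone. The step of a 1.1-fold lower number from compound 3 to compound 4 (0.04 log units; within the scatter) is expected to be small, within the scatter, with no clear direction. Compound 4 is expected to give about 22000 nM, within a range from 8000 nM to 50000 nM.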

Compound 4, half-maximal inhibitory concentration: 760 nM
For compound 4 the middle estimate is 29-fold (1.46 log units) above the measured one, and the stated range ends above it.
By their numbers in this assay, from the lowest: compound 4; then compound 2; then compound 3. At a limit, above all of these: compound 1.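

In this assay, the series now has its first single change that can be read, and this aromatic carbon of the fused two-ring system proves far from indifferent: hydrogen in place of fluoro gives a 32-fold lower number from compound 3 to compound 4 (1.50 log units; beyond the scatter). A second place on the molecule also responds, with methylsulfonyl in place of chloro on an aromatic carbon giving an at least 65-fold lower number from compound 1 to compound 4 (1.81 log units; beyond the scatter). The reading for compound 1 is a limit and not a number: the limit of > 50000 nM in this assay, at which 1 of the 4 values shown sits.

The compounds shown leave open whether a methoxy group or an amine on this same aromatic carbon would raise the number as fluoro does, or whether the rise is particular to fluoro. They also leave open how a carboxylic acid would read in place of methylsulfonyl, and they give no measured property that would explain either step.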